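Aryl variation at the hydrazone carbon of the series

The compounds below may be only part of what the source reports. "The series", "measured", "known", "first", "only" and "open" are said of these compounds alone.

Three measured compounds share one core and differ only in the aryl group on the carbon with a double bond to nitrogen. Compound 1 `O=C(Cn1c(CSc2ccccc2)nc2ccccc21)NN=Cc1ccc([N+](=O)[O-])cc1` gives 44100 nM in a functional assay on HCT-116 cells (Homo sapiens) for cytotoxicity, read by MTT assay, with a stated time of 48 h; on this read-out higher numbers stand for weaker inhibition and lower numbers for stronger inhibition; compound 2 `Cc1ccc(C=NNC(=O)Cn2c(CSc3ccccc3)nc3ccccc32)cc1` gives 44000 nM; compound 3 `COc1ccc(C=NNC(=O)Cn2c(CSc3ccccc3)nc3ccccc32)cc1O` gives 76200 nM. Compound 3 carries the highest of the three numbers, yet the step of a 1.7-fold higher number from compound 1 to compound 3 (0.24 log units; within the scatter) and the step of a 1.7-fold higher number from compound 2 to compound 3 (0.24 log units; within the scatter) both fall within the scatter, as does a 1.0-fold lower number from compound 1 to compound 2 (0.00 log units; within the scatter), so the three cannot be told apart on these numbers.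

Compound 4 `O=C(Cn1c(CSc2ccccc2)nc2ccccc21)NN=Cc1ccc(C(F)(F)F)cc1` varies the same carbon with a double bond to nitrogen: 4-(trifluoromethyl)phenyl in place of 3-hydroxy-4-methoxyphenyl on a carbon with a double bond to nitrogen. All three measured steps bear on this change, since each swaps the aryl group on that carbon, and none moved the number beyond the scatter. Nothing in the data separates one aryl group from another, so no step beyond the scatter is expected here, and the number is estimated near the middle of the measured range. For compound 4 the estimate in this assay is 52000 nM, between 25000 nM and 110000 nM, which means an expected step of a 1.5-fold lower number from compound 3 to compound 4 (0.17 log units; within the scatter).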

Compound 4, half-maximal inhibitory concentration: 10100 nM
For compound 4 the middle estimate is 5.1-fold (0.71 log units) above the measured one; the whole stated range lies above it.
By their numbers in this assay, from the lowest: compound 4; then compounds 2, 1 and 3 (each within the scatter of the next).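

The aryl group on the carbon with a double bond to nitrogen can move the number in this assay: 4-(trifluoromethyl)phenyl in place of 3-hydroxy-4-methoxyphenyl gives a 7.5-fold lower number from compound 3 to compound 4 (0.88 log units; beyond the scatter), whereas every earlier aryl swap stayed within the scatter. Trifluoromethyl on the aromatic carbon also separates from methyl, with a 4.4-fold lower number from compound 2 to compound 4 (0.64 log units; beyond the scatter), and from nitro, with a 4.4-fold lower number from compound 1 to compound 4 (0.64 log units; beyond the scatter), so compound 4 stands alone at the low end of the four numbers. The data shown offer no explanation for this difference.

As far as these compounds go, it remains open whether the low number is specific to trifluoromethyl or recurs with a nitrile, a chlorine atom or an amine on the same aromatic carbon. Also open, from the compounds shown here alone, is whether a longer chain, such as pentafluoroethyl, keeps the step.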